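The source may hold more compounds than are shown below. What is called first, only, known or untested is meant among the compounds shown, and "the series" means these compounds.

Measured in a functional assay on KB cells (Homo sapiens) for cytotoxicity, read by sulforhodamine B assay; on this read-out higher numbers stand for an effect only at larger amounts of compound and lower numbers for an effect already at smaller amounts:
Compound 1 `C=C1CC[C@@H]2[C@](C)(CO[Si](C)(C)C(C)(C)C)[C@H](O)CC[C@@]2(C)[C@@H]1C/C=C1/C(=O)OC[C@H]1OC(C)=O`: 10.7 uM
Compound 2 `C=C1CC[C@@H]2[C@](C)(CO[Si](C)(C)C(C)(C)C)[C@H](O)CC[C@@]2(C)[C@@H]1C/C=C1/C(=O)OC[C@H]1O`: 40.7 uM
Compound 3 `C=C1CC[C@@H]2[C@](C)(CO[Si](c3ccccc3)(c3ccccc3)C(C)(C)C)[C@H](O)CC[C@@]2(C)[C@@H]1C/C=C1/C(=O)OC[C@H]1O`: 11.1 uM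

Compound 2 gives the highest number of the three in this assay, with compound 3 and compound 1 both lower and beyond the scatter. Compound 4 `C=C1CC[C@@H]2[C@](C)(COC(C)=O)[C@H](O)CC[C@@]2(C)[C@@H]1C/C=C1/C(=O)OC[C@H]1O` differs from compound 2 by a group of 3 heavy atoms (2 carbon, 1 oxygen; no ring) in place of a group of 7 heavy atoms (6 carbon, 1 silicon; no ring), on an oxygen on a saturated carbon. For the measured compounds named here, no measured step changes this same group in this same way. The step of a 3.8-fold higher number from compound 1 to compound 2 (0.58 log units; beyond the scatter) concerns an acetyl on a different oxygen, and compound 2 against compound 3 shows that changing the group on this oxygen shifts the number. A modest lowering is therefore expected, but with wide uncertainty. Compound 4 is estimated at 15 uM in this assay, within 4 uM to 60 uM, a step of a 2.7-fold lower number from compound 2 to compound 4 (0.43 log units; beyond the scatter).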

Compound 4, concentration for half-maximal effect: 15.3 uM
Estimate against measurement, compound 4: 1.0-fold (0.01 log units) below; the range from low to high includes it.
By their numbers in this assay, from the lowest: compounds 1, 3 and 4 (each within the scatter of the next); then compound 2.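

In this assay, for the compounds shown here, the earlier compounds carried only silicon groups on this oxygen on a saturated carbon, and compound 4 shows that silicon is not required there: acetyl in its place gives a 2.7-fold lower number from compound 2 to compound 4 (0.42 log units; beyond the scatter). Compound 3 at 11.1 uM and compound 4 at 15.3 uM lie within the scatter of each other, despite their very different groups. No supporting data explain this step. Still open, as far as these compounds go, is how a benzoyl group, a longer ester chain or an amine would behave on this oxygen, and whether a bare hydroxyl there would give a similar number.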